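The compounds below may be only part of what the source reports. "The series", "measured", "known", "first", "only" and "open" are said of these compounds alone.

Measured so far in a functional assay on CHO cells with adenosine receptor A1 (Homo sapiens) as the target, read by cAMP accumulation and immunoassay, with a stated time of 6 min, tested at 1 uM; on this read-out lower numbers stand for a stronger effect and higher numbers for a weaker effect at the one concentration tested:
compound 1 `COc1ccc(N2CCN(Cc3csc(N)c3C(=O)c3ccc(Cl)cc3)CC2)cc1`: -15%
compound 2 `Nc1scc(CN2CCN(c3ccc(Cl)c(C(F)(F)F)c3)CC2)c1C(=O)c1ccc(Cl)cc1`: -47%

Compound 2 gives the lowest of the two numbers in this assay, and its step from compound 1 is beyond the scatter: a number 32 percentage points lower from compound 1 to compound 2 (beyond the scatter). Compound 3 `Nc1scc(CN2CCN(c3ccc(F)c(Cl)c3)CC2)c1C(=O)c1ccc(Cl)cc1` differs from compound 2 only at the group on the ring nitrogen: 3-chloro-4-fluorophenyl in place of 4-chloro-3-(trifluoromethyl)phenyl on an amine nitrogen in a ring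

Within the data shown here, the one measured step bearing on this position, a number 32 percentage points lower from compound 1 to compound 2 (beyond the scatter), shows that the aryl group on that nitrogen moves the read-out by a large amount. Compound 3 keeps a halogenated phenyl there, so only a modest shift toward weaker effect is expected: a number 12 percentage points higher from compound 2 to compound 3 (beyond the scatter). Compound 3 is estimated at -35%, within -60% to -10%.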

Compound 3, a percentage reported as activity, at one concentration (the size of the read-out at that concentration, not a potency): -60%
Compound 3: middle estimate off by 25 percentage points, on the high side, within the range that was stated.
By their numbers in this assay, from the lowest: compound 3; then compound 2; then compound 1.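

The change gives a number 13 percentage points lower from compound 2 to compound 3 (beyond the scatter) in this assay and so shows that the trifluoromethyl group is not required for a low number at this position: the 3-chloro-4-fluorophenyl group, with fewer heavy atoms, goes further. The same group gives a number 45 percentage points lower from compound 1 to compound 3 (beyond the scatter) against 4-methoxyphenyl, so both halogen-bearing phenyl groups shown lie beyond the scatter from the methoxy compound. No data at hand account for this order.

Open, from the compounds shown here alone, is whether the aromatic ring is needed on that nitrogen, as a benzyl or cyclohexyl group there would test. Also open, going by these compounds, is how a nitrile or an amine on the phenyl ring would compare with the halogens.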